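The compounds below may be only part of what the source reports. "The series", "measured", "known", "first", "only" and "open" are said of these compounds alone.

Compound 1 `Cc1cn([C@@H]2O[C@H](CO[Si](C)(C)C(C)(C)C)[C@@]3(OS(=O)(=O)C=C3NCC(N)=O)[C@H]2O[Si](C)(C)C(C)(C)C)c(=O)n(C)c1=O`: 13500 nM
Compound 2 `CC(=O)NC1=CS(=O)(=O)O[C@@]12[C@@H](CO[Si](C)(C)C(C)(C)C)O[C@@H](n1cc(C)c(=O)n(C)c1=O)[C@@H]2O[Si](C)(C)C(C)(C)C`: > 200000 nM, a limit of the assay
Compound 3 `Cc1cn([C@@H]2O[C@H](CO[Si](C)(C)C(C)(C)C)[C@@]3(OS(=O)(=O)C=C3NCC(=O)C(=O)O)[C@H]2O[Si](C)(C)C(C)(C)C)c(=O)n(C)c1=O`: 146000 nM

These three compounds were tested in a functional assay on HEL cells (Homo sapiens); on this read-out lower numbers stand for higher toxicity in this test and higher numbers for lower toxicity in this test. Only two of them have true numbers, and compound 3, at 146000 nM, has the higher of the two. Its nearest neighbour is compound 1, with an 11-fold higher number from compound 1 to compound 3 (1.03 log units; beyond the scatter). Compound 2 gives > 200000 nM, which is a limit and not a number.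

Compound 4 `Cc1cn([C@@H]2O[C@H](CO[Si](C)(C)C(C)(C)C)[C@@]3(OS(=O)(=O)C=C3NC(=O)c3ccccc3)[C@H]2O[Si](C)(C)C(C)(C)C)c(=O)n(C)c1=O` has benzoyl in place of (carboxycarbonyl)methyl on an amine nitrogen. Within the data shown here, no measured step makes this exact exchange. The closest guide is compound 2, which carries acetyl on that nitrogen. Replacing carbamoylmethyl with acetyl gave a large change, an at least 14-fold higher number from compound 1 to compound 2 (1.17 log units; beyond the scatter). The comparison of the acetyl and (carboxycarbonyl)methyl compounds gives an at least 1.3-fold lower number from compound 2 to compound 3 (0.13 log units; that floor lies within the scatter), so it separates them by no more than the scatter. Compound 4 is therefore expected to stay with compound 2 and compound 3 at the high end of this assay, not to fall towards compound 1, although benzoyl is larger than acetyl and the match is imperfect. The expected change, a 1.1-fold lower number from compound 3 to compound 4 (0.05 log units; within the scatter), is estimated to lie within the scatter. A reading at the limit would also be no surprise. The estimate for compound 4 is 130000 nM, within a range of 40000 nM to 200000 nM.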

Compound 4, half-maximal cytotoxic concentration: 9700 nM
The estimate for compound 4 lay 13-fold (1.13 log units) above the measured number, outside the stated range (below it).
By their numbers in this assay, from the lowest: compounds 4 and 1 (each within the scatter of the next); then compound 3. At a limit, above all of these: compound 2.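

On the amine nitrogen whose other neighbour is the double-bonded ring carbon, compound 4 shows that a carbonyl attached there does not by itself keep the number high in this assay: phenyl in place of methyl on that carbonyl carbon gives an at least 20-fold lower number from compound 2 to compound 4 (1.31 log units; beyond the scatter). Exchanging (carboxycarbonyl)methyl for benzoyl likewise gives a 15-fold lower number from compound 3 to compound 4 (1.18 log units; beyond the scatter), whereas exchanging carbamoylmethyl for benzoyl gives a 1.4-fold lower number from compound 1 to compound 4 (0.14 log units; within the scatter), so benzoyl and carbamoylmethyl, two quite different groups, leave compound 1 and compound 4 within the scatter of each other. The reading for compound 2 is a limit of the assay and not a number, so the step to compound 4 gives only a floor: the limit of > 200000 nM in this assay, at which 1 of the 4 values shown sits.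

The compounds shown leave open whether the aromatic ring of benzoyl goes with the lower number, a question that a cyclohexanecarbonyl group on the same nitrogen, or a phenylacetyl group with one more carbon before the ring, would address. They also do not tell whether groups placed on the phenyl ring, such as methoxy or chloro, would move the number in either direction.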